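Cytotoxicity of Compound 3 and Its Dimethylphenyl Analogue

The compounds below may be only part of what the source reports. "The series", "measured", "known", "first", "only" and "open" are said of these compounds alone.

Measured in a functional assay on C8166 cells (Homo sapiens) for cytotoxicity, read by MTT assay; on this read-out higher numbers stand for lower toxicity in this test and lower numbers for higher toxicity in this test:
compound 1 `Cc1cc(S(N)(=O)=O)ccc1NC(=O)COc1ccc(Cl)cc1NC(=O)c1ccccc1C`: 67300 nM
compound 2 `Cc1cccc(C(=O)Nc2cc(Cl)ccc2OCC(=O)Nc2ccc(S(N)(=O)=O)cc2C)c1`: 52900 nM
compound 3 `Cc1cc(S(N)(=O)=O)ccc1NC(=O)COc1ccc(Cl)cc1NC(=O)c1ccccc1[N+](=O)[O-]`: 54800 nM

Compound 3, at 54800 nM, is not separated from the other two measured compounds. The data show a 1.2-fold lower number from compound 1 to compound 3 (0.09 log units; within the scatter) and a 1.0-fold higher number from compound 2 to compound 3 (0.02 log units; within the scatter).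

Compound 4 `Cc1ccc(C)c(C(=O)Nc2cc(Cl)ccc2OCC(=O)Nc2ccc(S(N)(=O)=O)cc2C)c1` has not yet been measured. It carries 2,5-dimethylphenyl in place of 2-nitrophenyl on a carbonyl carbon. Within the data shown here, two measured steps bear on this change. The exchange between methyl and nitro on an aromatic carbon is the step already given from compound 1 to compound 3, here run in the opposite sense. Changing where the methyl sits gave a 1.3-fold lower number from compound 1 to compound 2 (0.10 log units; within the scatter). Among the measured compounds shown here, no measured compound carries 2,5-dimethylphenyl, so that exact group remains untested. Since all these steps stay within the scatter, no step beyond the scatter is expected in this assay. The expected outcome is a 1.1-fold higher number from compound 3 to compound 4 (0.02 log units; within the scatter). Compound 4 is estimated at 58000 nM, with an expected range of 35000 nM to 95000 nM.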

Compound 4, half-maximal cytotoxic concentration: 79700 nM
Beside the measured number, compound 4's estimate is 1.4-fold (0.14 log units) below it; the measured number falls inside the stated range.
By their numbers in this assay, from the lowest: compounds 2, 3, 1 and 4 (each within the scatter of the next).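

In this assay, exchanging 2-nitrophenyl for the all-carbon 2,5-dimethylphenyl on a carbonyl carbon gives a 1.5-fold higher number from compound 3 to compound 4 (0.16 log units; within the scatter) and so stays inside the usual variation of the test. Adding a second methyl to the singly methylated phenyl groups gives a 1.5-fold higher number from compound 2 to compound 4 (0.18 log units; within the scatter) and a 1.2-fold higher number from compound 1 to compound 4 (0.07 log units; within the scatter), which shows that, among these four compounds, this position takes two methyl groups as well as one methyl or a nitro without a step beyond the scatter. Nothing measured here offers an explanation for these numbers.

The compounds shown leave open whether a phenyl group on this carbonyl carbon carrying an amine, a carboxylic acid or a methoxy group would produce a step beyond the scatter in this assay. They also leave open how changes elsewhere on the shared core would read in this test.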